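The compounds below may be only part of what the source reports. "The series", "measured", "known", "first", "only" and "open" are said of these compounds alone.

Compound 1 `CCCSc1nc(Cl)c2c(n1)N(Cc1ccccc1)C(C(=O)N1CCN(C(=O)OC(C)(C)C)CC1)N2`: 31200 nM. Compound 2 `CCCSc1nc(Cl)c2c(n1)N(Cc1ccccc1)C(C(=O)O)N2`: > 64000 nM. Compound 3 `CCCSc1nc(Cl)c2c(n1)N(CC1CCCCC1)C(C(=O)N1CCN(C)CC1)N2`: > 64000 nM.

In a functional assay on TE-1 cells (Homo sapiens) for antiproliferative activity, read by MTT assay, with a stated time of 72 h (on this read-out higher numbers stand for weaker inhibition and lower numbers for stronger inhibition), compound 1 is the only one of the three to give a number, 31200 nM. For compound 2 the assay reports only a limit, > 64000 nM. Compound 3 likewise stops at a limit, > 64000 nM. Compound 2 therefore stands at the limit of > 64000 nM in this assay, at which 2 of the 3 values shown sit, with no number of its own to set against compound 1.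

Compound 4 `CCCSc1nc(Cl)c2c(n1)N(Cc1ccccc1)C(C(=O)NCCNC(=O)OC(C)(C)C)N2` is compound 2 with (2-((tert-butoxycarbonyl)amino)ethyl)amino in place of hydroxy on a carbonyl carbon. Within the data shown here, no measured pair shows this change directly. The nearest point of reference is compound 1, whose amide also carries a tert-butoxycarbonyl group and which gives 31200 nM in this assay. The free acid, compound 2, gives only a limit, > 64000 nM. On that basis compound 4 is expected to move from the limit toward a measurable value, a step of roughly an at least 1.6-fold lower number from compound 2 to compound 4 (0.22 log units; that floor lies within the scatter) toward stronger inhibition, though a limit remains a real possibility. The estimate for compound 4 in this assay is 38000 nM, with a range from 12000 nM to 90000 nM.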

Compound 4, half-maximal inhibitory concentration: > 64000 nM
Compound 4: no number, only a limit; the forecaster's own chance of this, stated with the estimate: 40%; middle value at least 1.6-fold (0.22 log units) from the limit.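

Compound 4 stops at a limit in this assay, > 64000 nM. Compound 2 also gives only a limit, so no step between compound 2 and compound 4 can be read: the limit of > 64000 nM in this assay, at which 3 of the 4 values shown sit.

On these data alone, whether (2-((tert-butoxycarbonyl)amino)ethyl)amino in place of hydroxy on a carbonyl carbon changes the read-out at all remains open.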